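Compound 2 to compound 4: one added group

The source may report more compounds than this note shows. Statements on the series, on what has been measured and on what is new or still open speak of the compounds shown alone.

For the measured compounds named here, in an ADME assay on BaF3 cells (Mus musculus) for inhibition, read by CellTiter-Glo, with a stated time of 72 h (on this read-out higher numbers stand for weaker inhibition of growth and lower numbers for stronger inhibition of growth), compound 2 (`CCN1CCN(C(=O)c2ccc(Nc3ncc4c(n3)N(C)C(=O)N(c3cc(NC(=O)c5cccc(C(F)(F)F)c5)ccc3C)C4)cn2)CC1`) gives 728 nM as the highest of the three numbers so far. Compound 3 (`CCN1CCN(c2ccc(Nc3ncc4c(n3)N(C)C(=O)N(c3cc(NC(=O)c5cccc(C(F)(F)F)c5)ccc3C)C4)cn2)CC1`) gives 264 nM and compound 1 (`CC(=O)N1CCN(c2ccc(Nc3ncc4c(n3)N(C)C(=O)N(c3cc(NC(=O)c5ccc(CN6CCC(N(C)C)C6)c(C(F)(F)F)c5)ccc3C)C4)cn2)CC1`) gives 187 nM on the same read-out. Compound 4 (`CCN1CCN(C(=O)c2ccc(Nc3ncc4c(n3)N(C)C(=O)N(c3cc(NC(=O)c5ccc(CN6CCC(N(C)C)C6)c(C(F)(F)F)c5)ccc3C)C4)cn2)CC1`) is still unmeasured. It differs from compound 2 in one place ((3-(dimethylamino)pyrrolidin-1-yl)methyl in place of hydrogen on an aromatic carbon): (3-(dimethylamino)pyrrolidin-1-yl)methyl in place of hydrogen on an aromatic carbon, ortho to a trifluoromethyl group.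

Going by the values given here, no measured pair makes exactly this change. Among the compounds with values here, the one measured step (a 2.8-fold lower number from compound 2 to compound 3 (0.44 log units; beyond the scatter)) concerns another part of the molecule, so it shows only that a single change can move the number here. The nearest evidence is compound 1, which already carries the entering group. Compound 1 at 187 nM and compound 3 at 264 nM lie within the usual scatter of each other, though they also differ in a second place, so this pair gives no sign of a large step. A small step towards a lower number is therefore expected in this assay, and it may stay within the scatter (a 1.8-fold lower number from compound 2 to compound 4 (0.26 log units; within the scatter)). For compound 4 the estimated value is 400 nM with an expected range from 160 nM to 900 nM on this read-out.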

Compound 4, concentration for 50% growth inhibition: 704 nM
Compound 4: the middle estimate sits 1.8-fold (0.25 log units) below what was measured; low and high end bracket the measured number.
By their numbers in this assay, from the lowest: compounds 1 and 3 (each within the scatter of the next); then compounds 4 and 2 (each within the scatter of the next).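

In this assay, putting (3-(dimethylamino)pyrrolidin-1-yl)methyl on this aromatic carbon, ortho to a trifluoromethyl group, gives a 1.0-fold lower number from compound 2 to compound 4 (0.01 log units; within the scatter). With (4-ethylpiperazin-1-yl)carbonyl at the far end of the molecule, this position therefore takes a sizeable new group, one with its own five-membered ring, and the number stays where it was. The other end still counts when the entering group is held constant: (4-ethylpiperazin-1-yl)carbonyl in place of 4-acetylpiperazin-1-yl gives a 3.8-fold higher number from compound 1 to compound 4 (0.58 log units; beyond the scatter), so the entering group alone does not set the number of compound 1. Nothing available here explains why the new group leaves the number unmoved.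

Going by these compounds, it remains open whether the entering group would also leave the number unmoved alongside the 4-ethylpiperazin-1-yl group of compound 3, or alongside 4-acetylpiperazin-1-yl. The compounds shown also say nothing about how a different substituent on this same carbon, such as a morpholin-4-ylmethyl group or a carboxylic acid, would read in this assay.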